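Swapping an Amide Link for a Sulfonamide in a Cytotoxicity Series

The source may report more compounds than this note shows. Statements on the series, on what has been measured and on what is new or still open speak of the compounds shown alone.

Compound 1 `Cc1ccc(S(=O)(=O)N[C@@H](CC(=O)NC(C)(C)C)C(=O)NCCNC(=O)c2c(O)cccc2F)cc1` was tested in an ADME assay on Karpas-1106P cells (Homo sapiens) for cytotoxicity; a higher number here means that more compound is needed for the effect, a lower number that less compound is needed. In this assay compound 1 gives > 11100 nM, which is a limit of the assay and not a number. Compound 2 `COc1cccc(C(=O)NCCNC(=O)[C@H](CC(=O)NC(C)(C)C)NS(=O)(=O)c2ccc(C)cc2)c1` gives > 11100 nM in this assay, likewise a limit. Compound 3 `Cc1ccc(S(=O)(=O)N[C@@H](CC(=O)NC(C)(C)C)C(=O)NCCNC(=O)NCc2ccccc2)cc1` gives > 11100 nM in this assay, again a limit. The steps from compound 1 to compound 2 (a step that the two limits leave unreadable from compound 1 to compound 2), from compound 1 to compound 3 (a step that the two limits leave unreadable from compound 1 to compound 3) and from compound 2 to compound 3 (a step that the two limits leave unreadable from compound 2 to compound 3) therefore cannot be sized, because of the limit of > 11100 nM in this assay, at which 3 of the 3 values shown sit.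

Compound 4 `Cc1ccc(S(=O)(=O)N[C@@H](CC(=O)NC(C)(C)C)C(=O)NCCNS(=O)(=O)c2ccccc2)cc1` carries a group of 9 heavy atoms (6 carbon, 2 oxygen, 1 sulfur; one six-membered aromatic ring of carbon only) in place of a group of 10 heavy atoms (7 carbon, 2 oxygen, 1 fluorine; one six-membered aromatic ring of carbon only), on an amine nitrogen. Nothing in these values shows whether such a change moves the read-out, so the expected step from compound 1 to compound 4, a step that the limit leaves unreadable from compound 1 to compound 4, is only an estimate. Compound 4 is expected to give 30000 nM in this assay, between 11100 nM and 100000 nM, most likely once more as a limit.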

Compound 4, half-maximal effective concentration: > 11100 nM
Compound 4 ended at the assay's limit; the forecaster's own chance of this, stated with the estimate: 85%; the middle value lies beyond the limit too.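

The steps from compound 1, compound 2 and compound 3 to compound 4 cannot be read, as all four values are limits and not numbers: the limit of > 11100 nM in this assay, at which 4 of the 4 values shown sit.

The compounds shown leave open whether any of these groups on the amine nitrogen changes the read-out in this assay.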